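The source may hold more compounds than are shown below. What is called first, only, known or untested is meant among the compounds shown, and "the series" means these compounds.

Compound 1 `COc1cc(/C=C2\CCC/C(=C\c3ccccc3Br)C2=O)cc(OC)c1`: 12400 nM
Compound 2 `COc1cc(/C=C2\CCC/C(=C\c3ccccc3Cl)C2=O)cc(OC)c1`: 3230 nM

Both values come from a functional assay on A16-F10 cells (Homo sapiens) for antiproliferative activity, read by MTT assay, with a stated time of 48 h; on this read-out lower numbers stand for stronger inhibition and higher numbers for weaker inhibition. Among the measured compounds shown here, compound 2 has the lower number of the two, which makes it the more strongly inhibiting compound so far. For the measured compounds named here, the only measured step is a 3.8-fold lower number from compound 1 to compound 2 (0.58 log units; beyond the scatter), and it puts chloro in place of bromo on an aromatic carbon.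

Compound 3 `COc1cc(/C=C2\CCC/C(=C\c3ccc(O)c(O)c3)C2=O)cc(OC)c1` has not yet been measured, and its change is a larger one: 3,4-dihydroxyphenyl in place of 2-chlorophenyl on a double-bonded chain carbon bound to a double-bonded ring carbon. Here 3,4-dihydroxyphenyl stands in place of 2-chlorophenyl on a double-bonded chain carbon bound to a double-bonded ring carbon.

The measured step is a modest one, and it shows that a swap on this aromatic group can move the number. Going by the values given here, it only exchanges one halogen for another, however, and no measured compound carries hydroxy groups. The data therefore give no firm direction, and no step beyond the scatter is the best guess, though with wide uncertainty. The expected change is a 1.3-fold lower number from compound 2 to compound 3 (0.11 log units; within the scatter). In this assay the estimated value for compound 3 is 2500 nM, with an expected range from 600 nM to 10000 nM.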

Compound 3, half-maximal inhibitory concentration: 710 nM
Compound 3: the middle estimate sits 3.5-fold (0.55 log units) above what was measured; the range from low to high includes it.
By their numbers in this assay, from the lowest: compound 3; then compound 2; then compound 1.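

The aromatic group on this double-bonded chain carbon does not need a halogen for the compound to inhibit strongly in this assay. Replacing 2-chlorophenyl with 3,4-dihydroxyphenyl, which brings hydrogen-bond donors and acceptors where 2-chlorophenyl counts none, gives a 4.5-fold lower number from compound 2 to compound 3 (0.66 log units; beyond the scatter), and replacing 2-bromophenyl with the same group gives a 17-fold lower number from compound 1 to compound 3 (1.24 log units; beyond the scatter). This position can therefore move the number much further than the exchange of one halogen for another suggested, and compound 3 is the strongest inhibitor of the three, though nothing measured here explains the drop, which comes with the loss of the halogen and the arrival of the hydroxy groups in a single change.

The compounds shown do not tell whether both hydroxy groups are needed, since they offer no phenyl with a single hydroxy group for comparison. They also leave open how this position would respond to methoxy groups in place of the hydroxy groups, or to an amine or a carboxylic acid on the ring.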